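A Nitro-to-Methyl Swap in a Level Series

A few compounds are considered here, and "the series" means these few. Any claim that something is new, unique, unknown or untested is made for them only; others in the source may bear on it.

- compound 1 `C[C@H]1CC[C@@H]2[C@@H](OC(=O)[C@]23CC(c2c(Cl)cccc2Cl)=NO3)[C@]2(C)C(=O)C=C[C@@]12O`: 38000 nM
- compound 2 `C[C@H]1CC[C@@H]2[C@@H](OC(=O)[C@]23CC(c2ccc(Cl)cc2)=NO3)[C@]2(C)C(=O)C=C[C@@]12O`: 43000 nM
- compound 3 `C[C@H]1CC[C@@H]2[C@@H](OC(=O)[C@]23CC(c2cccc([N+](=O)[O-])c2)=NO3)[C@]2(C)C(=O)C=C[C@@]12O`: 51000 nM

All three compounds share one core and differ only in the aromatic group, and all were tested in a functional assay on DU-145 cells (Homo sapiens) for cytotoxicity, read by sulforhodamine B assay, with a stated time of 48 h; on this read-out higher numbers stand for weaker inhibition and lower numbers for stronger inhibition. Compound 3 cannot be separated from the other two on these numbers. Its closest neighbour is compound 2, with a 1.2-fold higher number from compound 2 to compound 3 (0.07 log units; within the scatter), and its furthest is compound 1, with a 1.3-fold higher number from compound 1 to compound 3 (0.13 log units; within the scatter).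

The next compound, compound 4 `Cc1cccc(C2=NO[C@]3(C2)C(=O)O[C@@H]2[C@H]3CC[C@H](C)[C@]3(O)C=CC(=O)[C@@]23C)c1`, keeps the core and has methyl in place of nitro on an aromatic carbon, turning 3-nitrophenyl into 3-methylphenyl: methyl in place of nitro on an aromatic carbon.

Within the data shown here, no measured step makes this exact swap, and no measured compound carries methyl. The closest evidence is the set of changes to the aromatic group. Besides the two steps above, there is a 1.1-fold higher number from compound 1 to compound 2 (0.05 log units; within the scatter). All three stayed small, so no shift beyond the scatter is expected in this assay, and no direction is favoured. The expected step is a 1.1-fold lower number from compound 3 to compound 4 (0.05 log units; within the scatter). For compound 4 the estimated value is 45000 nM, with an expected range from 25000 nM to 80000 nM.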

Compound 4, half-maximal inhibitory concentration: 28000 nM
Beside the measured number, compound 4's estimate is 1.6-fold (0.21 log units) above it; the range from low to high includes it.
By their numbers in this assay, from the lowest: compounds 4, 1, 2 and 3 (each within the scatter of the next).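

The swap of nitro for methyl at this position, on an aromatic carbon meta to a large group, gives a 1.8-fold lower number from compound 3 to compound 4 (0.26 log units; within the scatter) in this assay. Among these compounds, this is the first direct reading of that change, and it shows that a group with hydrogen-bond acceptors can give way to a single carbon group with none while the number stays within the scatter. Compound 4 also stays level with the other two aromatic groups, with a 1.5-fold lower number from compound 2 to compound 4 (0.19 log units; within the scatter) and a 1.4-fold lower number from compound 1 to compound 4 (0.13 log units; within the scatter), so the 3-methylphenyl group joins the series without standing apart from it, and nothing measured on these compounds bears on what lies behind these numbers.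

On these data alone, it remains open whether an amine or a carboxylic acid on this aromatic ring, or a longer chain such as butyl in place of methyl, would move the number beyond the scatter. With all four compounds level in this assay, the compounds shown also leave open whether the aromatic group has any part in setting this level of activity.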